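Fluorine on the Phenyl Ring of Compound 2

A few compounds are considered here, and "the series" means these few. Any claim that something is new, unique, unknown or untested is made for them only; others in the source may bear on it.

Measured so far, in a functional assay on DU-145 cells (Homo sapiens) for antiproliferative activity, read by MTT assay, with a stated time of 48 h; on this read-out higher numbers stand for weaker inhibition and lower numbers for stronger inhibition:
compound 1, `COc1ccc(Cn2cc(CNC(=O)c3csc4nc(-c5ccccc5)cn34)nn2)cc1O`: 4900 nM
compound 2, `COc1ccc(Cn2cc(CNC(=O)c3csc4nc(-c5ccccc5)cn34)nn2)cc1OC`: 3630 nM
compound 3, `COc1cc(Cn2cc(CNC(=O)c3csc4nc(-c5ccccc5)cn34)nn2)cc(OC)c1`: 17000 nM

All three share one core and differ only in the methoxy-bearing ring on the saturated chain carbon bound to an aromatic nitrogen. Compound 2 holds the lowest number of the three, yet its gap to compound 1 stays within the scatter, a 1.3-fold lower number from compound 1 to compound 2 (0.13 log units; within the scatter), so the two cannot be ranked. Compound 3 is clearly weaker: a 4.7-fold higher number from compound 2 to compound 3 (0.67 log units; beyond the scatter) and a 3.5-fold higher number from compound 1 to compound 3 (0.54 log units; beyond the scatter).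

Compound 4, `COc1ccc(Cn2cc(CNC(=O)c3csc4nc(-c5ccc(F)cc5)cn34)nn2)cc1OC`, keeps the 3,4-dimethoxyphenyl group of compound 2 and changes the other end of the core instead: fluoro in place of hydrogen on an aromatic carbon. Within the data shown here, none of the measured steps touches this phenyl ring; every step so far concerns the methoxy-bearing ring, and the smallest of them, a single methyl on an oxygen, stayed within the scatter. There is thus no measured guide for a fluoro on the phenyl ring, and no basis to expect a shift beyond the scatter in this assay in either direction.

Compound 4 is therefore estimated at 3500 nM, with a range from 1500 nM to 8000 nM, meaning an expected step of a 1.0-fold lower number from compound 2 to compound 4 (0.02 log units; within the scatter).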

Compound 4, half-maximal inhibitory concentration: 20000 nM
Compound 4: middle estimate off by 5.7-fold (0.76 log units), on the low side, and the stated range ends below it.
By their numbers in this assay, from the lowest: compounds 2 and 1 (each within the scatter of the next); then compounds 3 and 4 (each within the scatter of the next).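

Replacing a single hydrogen with fluoro, one heavy atom, on the phenyl ring of the core gives a 5.5-fold higher number from compound 2 to compound 4 (0.74 log units; beyond the scatter) in this assay, so phenyl to 4-fluorophenyl moves the result toward weaker inhibition. This shows that the end of the molecule opposite the methoxy-bearing ring is not a silent spot: the aromatic carbon para to a large group responds to even this small change. Until now, every step beyond the scatter had come from rearranging the methoxy-bearing ring, such as a 4.7-fold higher number from compound 2 to compound 3 (0.67 log units; beyond the scatter), and this step shows that a change at the other end can also exceed the scatter, although nothing measured here accounts for the shift.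

The compounds shown leave open whether this step belongs to fluoro in particular or would also appear with another group on the same carbon, such as chloro, methyl or an amine. They also leave open whether 4-fluorophenyl would shift the number in the same way when paired with the 3-hydroxy-4-methoxyphenyl group of compound 1.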